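A few compounds are considered here, and "the series" means these few. Any claim that something is new, unique, unknown or untested is made for them only; others in the source may bear on it.

Measured so far:
- Compound 1 `CN(C)CC(=O)N1CCC(NS(=O)(=O)c2cc(S(=O)(=O)c3ccccc3)ccc2C(F)(F)F)CC1` gives 100000 nM in a physicochemical assay for solubility; a lower number here means a less soluble compound, a higher number a more soluble compound
- Compound 2 `CC(C)(C)CC(=O)N1CCC[C@H]1C(=O)N1CCC(NS(=O)(=O)c2cc(S(=O)(=O)c3ccccc3)ccc2C(F)(F)F)CC1` gives 25000 nM in this assay
- Compound 3 `CN(C)c1ccc(C(=O)N2CCC[C@H]2C(=O)N2CCC(NS(=O)(=O)c3cc(S(=O)(=O)c4ccccc4)ccc3C(F)(F)F)CC2)cc1` gives 100000 nM in this assay

Compound 3 stands level with compound 1 at the digits shown, the two sharing the highest of the three numbers, while compound 2 lies lower. Compound 4 `CC(C)(C)NC(=O)N1CCC[C@H]1C(=O)N1CCC(NS(=O)(=O)c2cc(S(=O)(=O)c3ccccc3)ccc2C(F)(F)F)CC1` differs from compound 3 by having (tert-butyl)amino in place of 4-(dimethylamino)phenyl on a carbonyl carbon, and the full count reads (tert-butyl)amino in place of 4-(dimethylamino)phenyl on a carbonyl carbon in this exchange.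

The closest measured step is a 4.0-fold higher number from compound 2 to compound 3 (0.60 log units; beyond the scatter), where the same 4-(dimethylamino)phenyl took the place of neopentyl on a carbonyl carbon. Step a 4.0-fold lower number from compound 1 to compound 2 (0.60 log units; beyond the scatter) is of similar size but changes a larger part of the structure, so it bears only indirectly. Read in reverse, the closest step points to a lower number once 4-(dimethylamino)phenyl leaves for a group with no ring. Neopentyl and (tert-butyl)amino are different groups, however, so compound 4 is expected near compound 2, at 25000 nM, and perhaps somewhat higher.

A modest downward move is therefore expected in this assay, with a 2.5-fold lower number from compound 3 to compound 4 (0.40 log units; beyond the scatter) as the estimated step. The estimate for compound 4 is 40000 nM, with an expected range from 15000 nM to 100000 nM as its bounds.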

Compound 4, solubility: 50000 nM
Compound 4: the middle estimate sits 1.3-fold (0.10 log units) below what was measured; low and high end bracket the measured number.
By their numbers in this assay, from the lowest: compounds 2, 4, 1 and 3 (each within the scatter of the next, the first and the last beyond it).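

In this assay, putting (tert-butyl)amino on the carbonyl carbon in place of 4-(dimethylamino)phenyl gives a 2.0-fold lower number from compound 3 to compound 4 (0.30 log units; within the scatter), so at this place a group with no ring does not move the number beyond the scatter. Against neopentyl on the same carbonyl carbon, (tert-butyl)amino gives a 2.0-fold higher number from compound 2 to compound 4 (0.30 log units; within the scatter), and the wider exchange of (dimethylamino)methyl for 1-((tert-butyl)carbamoyl)pyrrolidin-2-yl gives a 2.0-fold lower number from compound 1 to compound 4 (0.30 log units; within the scatter). Compound 4 thus lies within the scatter of compound 1, compound 2 and compound 3 alike, although compound 2 stands beyond the scatter of the other two, and nothing measured here accounts for this.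

The exchange from compound 3 to compound 4 removes the aromatic ring and brings in the amide hydrogen together, so the compounds shown do not separate these two differences. Also open, from the compounds shown here alone, is how a simple methylamino group, a carboxylic acid or a longer chain on this carbonyl carbon would read in this assay.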